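From benzyl to methoxycarbonyl on the saturated ring

The source may report more compounds than this note shows. Statements on the series, on what has been measured and on what is new or still open speak of the compounds shown alone.

Measured in a functional assay on SH-SY5Y cells (Homo sapiens) for inhibition, read by sulforhodamine B assay; on this read-out higher numbers stand for weaker inhibition and lower numbers for stronger inhibition:
- compound 1 `COC(=O)CC/C(C)=C/Cc1c(OC)c(C)c2c(c1OCC#CCN1CCN(c3ccc(C#N)cc3)CC1)C(=O)OC2`: 37800 nM
- compound 2 `COC(=O)CC/C(C)=C/Cc1c(OC)c(C)c2c(c1OCC#CCN1CCN(c3ccccc3OC)CC1)C(=O)OC2`: 43600 nM
- compound 3 `COC(=O)CC/C(C)=C/Cc1c(OC)c(C)c2c(c1OCC#CCN1CCC(Cc3ccccc3)CC1)C(=O)OC2`: 24500 nM

Compound 3, at 24500 nM, stands within the scatter of both compound 1 and compound 2, so the three values set no order among these compounds. Compound 4 `COC(=O)CC/C(C)=C/Cc1c(OC)c(C)c2c(c1OCC#CCN1CCC(C(=O)OC)CC1)C(=O)OC2` has methoxycarbonyl in place of benzyl on a saturated ring carbon. Among the compounds with values here, the one measured step available is a 1.2-fold higher number from compound 1 to compound 2 (0.06 log units; within the scatter). It lies within the scatter, but it swaps 4-cyanophenyl for 2-methoxyphenyl on an amine nitrogen in a ring, so it bears on this change only indirectly. Within the data shown here, no measured step changes the group on the saturated ring carbon, and the data therefore give no direct guide. In this assay, a step no larger than the scatter is expected, with no firm direction. The expected step is a 1.4-fold higher number from compound 3 to compound 4 (0.15 log units; within the scatter). For compound 4 the estimated value is 35000 nM, with an expected range from 15000 nM to 80000 nM.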

Compound 4, half-maximal inhibitory concentration: 41200 nM
For compound 4 the middle estimate is 1.2-fold (0.07 log units) below the measured one, within the range that was stated.
By their numbers in this assay, from the lowest: compounds 3, 1, 4 and 2 (each within the scatter of the next).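

Replacing benzyl, with its six-membered aromatic ring, by methoxycarbonyl, which has no ring and brings two hydrogen-bond acceptors, gives a 1.7-fold higher number from compound 3 to compound 4 (0.23 log units; within the scatter) in this assay. On this saturated ring carbon, three ring bonds from the ring nitrogen, the two groups therefore cannot be told apart on this read-out, and the aromatic ring of benzyl is not required for compound 4 to stay within the scatter of compound 3. Nothing available explains why these two different groups read alike.

The compounds shown leave open whether a carboxylic acid, a primary amine or a longer chain on this carbon would also stay within the scatter of compound 3. They also leave open whether any group at this position can produce a step beyond the scatter.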